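From Methyl Ester to Benzyl Ester on the Shared Core

The compounds below may be only part of what the source reports. "The series", "measured", "known", "first", "only" and "open" are said of these compounds alone.

Of the compounds shown here, three built on one shared core have so far been measured in an ADME assay on HEK293 cells (Homo sapiens) for inhibition, read by CellTiter-Glo, with a stated time of 96 h, tested at 100 uM; a lower number here means less inhibition, a higher number more inhibition at the concentration tested (going by the name of the read-out). Compound 1 `CC(C)(C)OC(=O)/C=C\NC(=O)[C@@H](O)C(C)(C)CO` gives -11%, compound 2 `CCOC(=O)/C=C\NC(=O)[C@@H](O)C(C)(C)CO` gives -6%, and compound 3 `COC(=O)/C=C\NC(=O)[C@@H](O)C(C)(C)CO` gives -12%. Compound 3 holds the lowest of the three numbers, yet its neighbours sit within the scatter: a number 1 percentage points lower from compound 1 to compound 3 (within the scatter), and a number 6 percentage points lower from compound 2 to compound 3 (within the scatter). The remaining step, a number 5 percentage points higher from compound 1 to compound 2 (within the scatter), is likewise within the scatter.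

Compound 4 `CC(C)(CO)[C@H](O)C(=O)N/C=C\C(=O)OCc1ccccc1` has not yet been measured. It differs from compound 3 by phenyl in place of hydrogen on a saturated chain carbon bound to an oxygen next to a carbonyl group. The measured steps that bear on this change all alter the group on an oxygen next to a carbonyl group, moving between tert-butyl, ethyl and methyl, and none of them shifted the number beyond the scatter. Going by the values given here, no measured step adds a phenyl ring, so the expectation rests on those flat steps. The step of a number 3 percentage points higher from compound 3 to compound 4 (within the scatter) is expected to be none beyond the scatter. Compound 4 is therefore estimated at -9%, within a range from -22% to 5%.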

Compound 4, a percentage reported as inhibition, at one concentration (the size of the read-out at that concentration, not a potency): -7%
Beside the measured number, compound 4's estimate is 2 percentage points below it; low and high end bracket the measured number.
By their numbers in this assay, from the lowest: compounds 3, 1, 4 and 2 (each within the scatter of the next).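

In this assay, going from methyl to benzyl gives a number 5 percentage points higher from compound 3 to compound 4 (within the scatter) and shows that an aromatic ring can sit at this position without moving the number beyond the scatter. The comparisons with the other two esters agree, with a number 1 percentage points lower from compound 2 to compound 4 (within the scatter) and a number 4 percentage points higher from compound 1 to compound 4 (within the scatter) so that methyl, ethyl, tert-butyl and benzyl all give numbers within the scatter of one another on the shared core. Nothing measured here explains why this position stays so flat across these four groups.

The groups shown on this oxygen contain only carbon and hydrogen, so it remains open whether a chain carrying an amine would also stay within the scatter. The same question stands for a carboxylic acid, where a hydrogen replaces the whole group on that oxygen.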